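Replacing the amide with a hydroxyethoxy-substituted benzyl group

The source may report more compounds than this note shows. Statements on the series, on what has been measured and on what is new or still open speak of the compounds shown alone.

Measured compounds:
compound 1 `CC(C)c1onc(-c2c(Cl)cccc2Cl)c1COc1ccc(N(C)C(=O)c2ccc(C(=O)O)cc2)c(C(F)(F)F)n1`, 235 nM
compound 2 `CC(C)c1onc(-c2c(Cl)cccc2Cl)c1COc1ccc(NCc2ccc(C(=O)O)cc2)c(C(F)(F)F)n1`, 162 nM

In an assay on isolated protein for agonist activity at Bile acid receptor (Homo sapiens), read by FRET (a lower number here means that less compound is needed, a higher number that more compound is needed for the effect), compound 1 gives 235 nM, the higher of the two numbers, while compound 2 gives 162 nM, a gap that lies within the scatter. Compound 3 `CC(C)c1onc(-c2c(Cl)cccc2Cl)c1COc1ccc(N(C)Cc2ccc(OCCO)cc2)c(C(F)(F)F)n1` differs from compound 1 in one place: 4-(2-hydroxyethoxy)benzyl in place of (4-carboxyphenyl)carbonyl on a nitrogen on an aromatic ring. Going by the values given here, no measured pair shows a comparable change. The step is expected to go towards a higher number, estimated as a 3.4-fold higher number from compound 1 to compound 3 (0.53 log units; beyond the scatter), with wide uncertainty. Compound 3 is expected to give 800 nM in this assay, between 200 nM and 4000 nM.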

Compound 3, half-maximal effective concentration: 164 nM
For compound 3 the middle estimate is 4.9-fold (0.69 log units) above the measured one; measured number outside the range, below it.
By their numbers in this assay, from the lowest: compounds 2, 3 and 1 (each within the scatter of the next).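

In this assay, 4-(2-hydroxyethoxy)benzyl in place of (4-carboxyphenyl)carbonyl on a nitrogen on an aromatic ring gives a 1.4-fold lower number from compound 1 to compound 3 (0.16 log units; within the scatter). At this position, then, a compound without the carboxylic acid and the carbonyl still reads within the scatter of compound 1. Neither earlier compound could show this. Both carry the acid. Nothing at hand explains this result.

What the 2-hydroxyethoxy group itself contributes remains open, since the compounds shown do not separate it from the benzyl group. A methoxy group, an amine or a longer chain in its place would test this.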